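Replacing a hydroxyphenyl with a fluorophenyl on a quinazoline amine

The source may report more compounds than this note shows. Statements on the series, on what has been measured and on what is new or still open speak of the compounds shown alone.

Measured compounds:
compound 1, `COc1cc(C2N(c3ccc(C)cc3)CCN2c2ccc(C)cc2)ccc1O`, 27600 nM
compound 2, `Oc1cccc(Nc2nc(NCc3ccccc3)c3ccccc3n2)c1`, 15800 nM
compound 3, `O=[N+]([O-])c1cccnc1Sc1ccccc1NS(=O)(=O)c1ccc(Cl)cc1Cl`, 63100 nM

Of the compounds shown here, three of unrelated build have been tested in a functional assay on HT-29 cells (Homo sapiens) for antiproliferative activity, read by MTT assay; on this read-out higher numbers stand for weaker inhibition and lower numbers for stronger inhibition. Compound 2 gives the lowest of the three numbers; compound 1 sits within the usual scatter of it, so the two cannot be told apart, while compound 3 lies beyond the scatter with a higher number. Compound 4, `Fc1ccc(Nc2nc(NCc3ccccc3)c3ccccc3n2)cc1`, differs from compound 2 in one place: 4-fluorophenyl in place of 3-hydroxyphenyl on a nitrogen on an aromatic ring. Within the data shown here, no pair of measured compounds shows what such a change does, so the size of the step has to be guessed. Since nothing measured speaks for a change in either direction, the step from compound 2 to compound 4 is expected to stay within the scatter, most likely as a slight move toward a higher number, and the estimate is a 1.4-fold higher number from compound 2 to compound 4 (0.14 log units; within the scatter). In this assay compound 4 is expected to give about 22000 nM, with a likely range from 6000 nM to 80000 nM.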

Compound 4, half-maximal inhibitory concentration: 2410 nM
Compound 4: middle estimate off by 9.1-fold (0.96 log units), on the high side; measured number outside the range, below it.
By their numbers in this assay, from the lowest: compound 4; then compounds 2 and 1 (each within the scatter of the next); then compound 3.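

In this assay the group on this nitrogen turns out to matter: a 6.6-fold lower number from compound 2 to compound 4 (0.82 log units; beyond the scatter) follows from putting 4-fluorophenyl in place of 3-hydroxyphenyl, a step beyond the scatter that the three unrelated earlier compounds could not reveal. By the computed counts, the ring that enters has lost the hydrogen-bond donor and acceptor of the ring that leaves, while its size stays the same. Nothing available explains the gain in this series, and this single pair cannot supply a reason.

The two group names differ both in the substituent and in the number that places it on the ring, so this pair cannot separate those two changes. From the compounds shown here alone, how a plain phenyl, or a phenyl carrying a chlorine, a methoxy group or an amine, would compare on this nitrogen remains open.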